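A few compounds are considered here, and "the series" means these few. Any claim that something is new, unique, unknown or untested is made for them only; others in the source may bear on it.

Compound 1 `CC(=O)c1ccc(NC(=O)CSC(=S)N[C@H]2CCOC2=O)cc1` carries a methyl on a carbonyl carbon. In a functional assay on SMMC-7721 cells (Homo sapiens) for cytotoxicity, read by MTT assay, with a stated time of 72 h (on this read-out lower numbers stand for stronger inhibition and higher numbers for weaker inhibition), compound 1 gives > 128000 nM, which is a limit of the assay and not a number. Compound 2 `O=C(CSC(=S)N[C@H]1CCOC1=O)Nc1ccc(C(=O)/C=C/c2ccccc2)cc1` has 2-phenylethenyl in place of that methyl. In this assay compound 2 gives > 128000 nM, again a limit rather than a number. The step that the two limits leave unreadable from compound 1 to compound 2 cannot be read because of the limit of > 128000 nM in this assay, at which 2 of the 2 values shown sit. Compound 3 `O=C(CSC(=S)N[C@H]1CCOC1=O)Nc1ccc(C(=O)/C=C/c2ccc(Br)cc2)cc1` differs from compound 2 by bromo in place of hydrogen on an aromatic carbon. Within the data shown here, no measured step bears on this change, and compound 2 stands only at a limit. The step of an at least 1.4-fold lower number from compound 2 to compound 3 (0.15 log units; that floor lies within the scatter) is expected to be small. Compound 3 is estimated at 90000 nM, between 25000 nM and 400000 nM.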

Compound 3, half-maximal inhibitory concentration: 18000 nM
Compound 3: middle estimate off by 5.0-fold (0.70 log units), on the high side; measured number below the stated range.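

Bromo on an aromatic carbon, para to a large group, gives the first readable value in the series in this assay, with an at least 7.1-fold lower number from compound 2 to compound 3 (0.85 log units; beyond the scatter). Set against the methyl of compound 1, the full 2-(4-bromophenyl)ethenyl group gives an at least 7.1-fold lower number from compound 1 to compound 3 (0.85 log units; beyond the scatter). The step from compound 1 to compound 2 still cannot be read: the limit of > 128000 nM in this assay, at which 2 of the 3 values shown sit.

Going by these compounds, the full size of both readable steps remains open, as compound 1 and compound 2 stand only at limits. Also open, on these data alone, is whether chloro, methoxy or an amine at this para place would match bromo.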